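The source may report more compounds than this note shows. Statements on the series, on what has been measured and on what is new or still open speak of the compounds shown alone.

Measured compounds:
- compound 1, `Cc1noc(C)c1-c1cccc(Oc2ccc(C#N)c(C(F)(F)F)c2)c1`: "not determined" (no result reported)
- compound 2, `CCN(c1ccc(C#N)c(Cl)c1)c1cc(-n2cnc3ccccc32)ccc1C`: 3040 nM

Compound 1 carries no result in a functional assay on CWR22R cells (Homo sapiens) for antiproliferative activity, read by CCK-8 assay, with a stated time of 6 days; on this read-out lower numbers stand for stronger inhibition and higher numbers for weaker inhibition; for compound 1 nothing further can be said. Within the data shown here, compound 2 is the only compound with a number here, so in this assay compound 2 gives 3040 nM and there is no second value to set against it; no step between measured compounds is available, and nothing about the usual size of such steps is known.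

Compound 3, `CCN(c1ccc(C#N)c(Cl)c1)c1cc(-c2cccnc2)ccc1C`, is not yet measured. It differs from compound 2 at one place: pyridin-3-yl in place of 1H-benzimidazol-1-yl on an aromatic carbon. The group that leaves, 1H-benzimidazol-1-yl, is larger than the group that enters, pyridin-3-yl, and the site of the change is the same aromatic carbon in both.

With no step shown, the expectation for this change rests on compound 2 alone. The step from compound 2 to compound 3 is estimated as a 1.2-fold higher number from compound 2 to compound 3 (0.06 log units; within the scatter), expected to lie within the scatter rather than beyond it. Compound 3 is therefore expected to give roughly 3500 nM in this assay, with a range from 1200 nM to 10000 nM.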

Compound 3, half-maximal inhibitory concentration: 2000 nM
For compound 3 the middle estimate is 1.8-fold (0.24 log units) above the measured one; the measured number falls inside the stated range.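

In this assay, among these compounds, the exchange of 1H-benzimidazol-1-yl for pyridin-3-yl, on the aromatic carbon that is meta to a large group and para to a methyl group, gives a 1.5-fold lower number from compound 2 to compound 3 (0.18 log units; within the scatter) and so provides the first step, one that leaves compound 2 and compound 3 indistinguishable on this read-out. At this position, a substituent with a five-membered and a six-membered aromatic ring and a substituent with a single six-membered aromatic ring thus give values within the scatter of each other, although the heavy-atom count and the hydrogen-bond acceptor count both differ; this holds for this one pair only. Nothing measured here accounts for this closeness of the two values.

Still open, as far as these compounds go, is whether a non-aromatic group at the same carbon, such as a primary amine, a carboxylic acid or a morpholine ring, would move the number beyond the scatter. Also open, from the compounds shown here alone, is whether a phenyl ring, or pyridin-2-yl or pyridin-4-yl, would stay as close to compound 3 as compound 2 does.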